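The source may hold more compounds than are shown below. What is called first, only, known or untested is meant among the compounds shown, and "the series" means these compounds.

Series notes, read in a functional assay on NCI-H460 cells (Homo sapiens) for inhibition, read by MTT assay, with a stated time of 24 h, tested at 10 ug/mL; on this read-out lower numbers stand for less inhibition of growth and higher numbers for more inhibition of growth at the one concentration tested. Compound 1 (`O=C(CCCCC1CCSS1)NO`) gives "not active" (no number reported), and compound 2 (`O=C(CCCCC1CCSS1)Nc1ccc([N+](=O)[O-])c(C(F)(F)F)c1`) gives 12%. Among the measured compounds shown here, compound 3 (`O=C(CCCCC1CCSS1)Nc1ccccn1`) gives "not active" (no number reported), so it has no single number and shares that standing with compound 1, while compound 2 holds the only number. Compound 4 (`O=C(CCCCC1CCSS1)Nc1ccc(Cl)cn1`) differs from compound 3 by chloro in place of hydrogen on an aromatic carbon. For the measured compounds named here, no measured step is available for this change. From compound 3 at "not active" (no number reported), a small rise in growth inhibition is expected, probably none beyond the usual scatter. For compound 4 the estimated value is 8%, with an expected range of 0% to 20%.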

Compound 4, percent growth inhibition at one concentration: 33.7%
Beside the measured number, compound 4's estimate is 25.7 percentage points below it; measured number above the stated range.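

Among the compounds shown here, compound 3 has no single number in this assay, and no step to compound 4 can be read. The compounds shown leave open how much chloro in place of hydrogen changes growth inhibition. No available data explain the result.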